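This account rests on a few compounds, and the source may have more. Where it says the series, first, only, none or still open, it means among the compounds named here.

Compound 1, `CCCCc1oc2ccccc2c1C(=O)c1ccc(OCC(N)=O)cc1`, gives > 50000 nM in a functional assay on MDA-MB-231 cells (Homo sapiens) for antiproliferative activity, read by MTT assay, with a stated time of 24 h; a lower number here means a stronger inhibitor, a higher number a weaker inhibitor; this is a limit of the assay and not a number.
Compound 2, `CCCCc1oc2ccccc2c1C(=O)c1ccc(OCC(=O)Nc2ccccc2)cc1`, gives > 50000 nM in this assay; this too is a limit and not a number.

Compound 2 thus stands at the limit of > 50000 nM in this assay, at which 2 of the 2 values shown sit, and the other value shown sits there as well, so nothing in these numbers places compound 2 as stronger or weaker than compound 1. For the measured compounds named here, the one measured step, a step that the two limits leave unreadable from compound 1 to compound 2, cannot be sized: both of its ends are limits.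

Compound 3, `CCCCNC(=O)CCCOc1ccc(C(=O)c2c(CCCC)oc3ccccc23)cc1`, has not yet been tested in this assay. It differs from compound 2 by 2-(butylcarbamoyl)ethyl in place of phenylcarbamoyl on a saturated chain carbon bound to an oxygen on an aromatic ring. Going by the values given here, no measured step bears on this change: the only step available is unreadable, so neither a direction nor a size can be taken from it. With both measured compounds resting at the limit, the expectation for compound 3 is that it also stays around that limit. The expected step, a step that the limit leaves unreadable from compound 2 to compound 3, is therefore none beyond the scatter. Compound 3 is estimated at 60000 nM, with a range from 20000 nM to 200000 nM.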

Compound 3, half-maximal inhibitory concentration: 38100 nM
Beside the measured number, compound 3's estimate is 1.6-fold (0.20 log units) above it; the range from low to high includes it.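

In this assay compound 3 gives 38100 nM, the first result in this set that is a number and not a limit, with 2-(butylcarbamoyl)ethyl in place of phenylcarbamoyl on a saturated chain carbon bound to an oxygen on an aromatic ring. Set against the two limits, this change reads as an at least 1.3-fold lower number from compound 2 to compound 3 (0.11 log units; that floor lies within the scatter), and the replacement of carbamoyl by the same group reads as an at least 1.3-fold lower number from compound 1 to compound 3 (0.11 log units; that floor lies within the scatter), so the numbers establish no real gain in strength, only a first readable value, while compound 1 and compound 2 remain limits: the limit of > 50000 nM in this assay, at which 2 of the 3 values shown sit.

The compounds shown do not separate the butyl group on the amide nitrogen from the longer chain that carries the amide; compound 3 alters both at once, and the loss of the phenyl ring comes with them. Also open, on these data alone, is how a piperidine amide, or a carboxylic acid or an amine in place of the amide, would read in this assay.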